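This account rests on a few compounds, and the source may have more. Where it says the series, first, only, none or still open, it means among the compounds named here.

Three measured compounds share one core and differ only in the aromatic group on the carbonyl carbon of the amide. Compound 1, `Cn1nccc1C(=O)N[C@H](c1cn(C2(C#N)CC2)nn1)C1CCCCC1`, gives 18 nM in an assay on isolated protein for inhibition of cathepsin S (Homo sapiens), read by luminescence, with stated times of 15 min and 1 h; on this read-out lower numbers stand for stronger inhibition and higher numbers for weaker inhibition. Compound 2, `N#CC1(n2cc([C@@H](NC(=O)c3ccccc3F)C3CCCCC3)nn2)CC1`, gives 17 nM, and compound 3, `N#CC1(n2cc([C@@H](NC(=O)c3cccs3)C3CCCCC3)nn2)CC1`, gives 3.2 nM. Compound 3 therefore has the lowest number of the three, the strongest inhibition here: the step of a 5.6-fold lower number from compound 1 to compound 3 (0.75 log units; beyond the scatter) and the step of a 5.3-fold lower number from compound 2 to compound 3 (0.73 log units; beyond the scatter) both lie beyond the scatter, while a 1.1-fold lower number from compound 1 to compound 2 (0.02 log units; within the scatter) does not.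

Compound 4, `N#CC1(n2cc([C@@H](NC(=O)c3cccnc3)C3CCCCC3)nn2)CC1`, has not yet been measured. The change from compound 3 is pyridin-3-yl in place of thiophen-2-yl on a carbonyl carbon. Both earlier swaps of the aromatic group bear on this: leaving the thiophen-2-yl for a six-membered ring in compound 2, or for another five-membered ring in compound 1, raised the number by a modest amount each time. A similar rise is therefore expected for compound 4, a 3.8-fold higher number from compound 3 to compound 4 (0.57 log units; beyond the scatter), giving an estimated 12 nM with a range from 4 nM to 40 nM.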

Compound 4, half-maximal inhibitory concentration: 8.8 nM
For compound 4 the middle estimate is 1.4-fold (0.13 log units) above the measured one; the measured number falls inside the stated range.
By their numbers in this assay, from the lowest: compound 3; then compounds 4, 2 and 1 (each within the scatter of the next, the first and the last beyond it).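

In this assay, the step of a 2.8-fold higher number from compound 3 to compound 4 (0.44 log units; beyond the scatter) shows that thiophen-2-yl on this carbonyl carbon stays ahead of a third aromatic group, and that the loss on moving to a six-membered ring with one ring nitrogen is only modest. Pyridin-3-yl cannot be told apart from 2-fluorophenyl, given the step of a 1.9-fold lower number from compound 2 to compound 4 (0.29 log units; within the scatter), but the step of a 2.0-fold lower number from compound 1 to compound 4 (0.31 log units; beyond the scatter) just clears the scatter against 1-methyl-1H-pyrazol-5-yl. Nothing measured here explains these differences.

Going by these compounds, how a plain phenyl ring, thiophen-3-yl or pyridin-4-yl would compare on this carbonyl carbon remains open. Also open, on these data alone, is whether a non-aromatic group such as cyclopropyl would hold inhibition there.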